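The source may hold more compounds than are shown below. What is called first, only, known or untested is meant among the compounds shown, and "the series" means these compounds.

In a functional assay on isolated protein for agonist activity at Glucose-dependent insulinotropic receptor (Rattus norvegicus), read by HTRF and cAMP accumulation (on this read-out higher numbers stand for an effect only at larger amounts of compound and lower numbers for an effect already at smaller amounts), compound 1 `CC(C)(C)OC(=O)N1CCC(O[C@H]2CC[C@H](Oc3ccc(S(C)(=O)=O)cn3)CC2)CC1` gives 110 nM, and compound 2 `CC1(OC(=O)N2CCC(O[C@H]3CC[C@H](Oc4cnc(S(C)(=O)=O)cn4)CC3)CC2)CC1` gives 138 nM; the two numbers lie within the usual scatter of each other, so neither compound can be set apart from the other on this read-out. Compound 3 `CS(=O)(=O)c1cnc(O[C@H]2CC[C@H](OC3CCN(C(=O)Oc4ccccc4)CC3)CC2)cn1` has not been measured yet. It differs from compound 2 by phenyl in place of 1-methylcyclopropyl on an oxygen next to a carbonyl group. Among the measured compounds shown here, no measured pair shows this change, so the expected step is a 1.4-fold higher number from compound 2 to compound 3 (0.16 log units; within the scatter), a small move toward a larger number at most and not clearly beyond the scatter. On that basis compound 3 is estimated to give 200 nM, within a range of 70 nM to 600 nM.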

Compound 3, half-maximal effective concentration: 71.8 nM
Compound 3: middle estimate off by 2.8-fold (0.44 log units), on the high side, and the stated range covers the measured number.
By their numbers in this assay, from the lowest: compounds 3, 1 and 2 (each within the scatter of the next).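

Putting phenyl in place of 1-methylcyclopropyl on an oxygen next to a carbonyl group gives a 1.9-fold lower number from compound 2 to compound 3 (0.28 log units; within the scatter) in this assay. This position therefore accepts a six-membered aromatic ring of carbon as well as a three-membered non-aromatic one, with no step beyond the scatter. Nothing at hand accounts for the size of this step. As far as these compounds go, what a benzyl group or a pyridyl ring would do on this oxygen remains open, and so does whether the same step holds on the core of compound 1.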